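From Bromo to Chloro on a Hydroxyphenyl Group

This account rests on a few compounds, and the source may have more. Where it says the series, first, only, none or still open, it means among the compounds named here.

Of the compounds shown here, two built on one shared core have numbers so far in an ADME assay on microsomes from liver (Homo sapiens) for metabolic stability, read by HPLC, with a stated time of 30 min, tested at 0.5 uM; a higher number here means faster removal of the compound, a lower number slower removal. Compound 1 (`CCC/N=C1\S/C(=C\c2ccc(O)c(C(F)(F)F)c2)C(=O)N1c1ccccc1C`) gives 1 mL.min-1.g-1, and compound 2 (`CCC/N=C1\S/C(=C\c2ccc(O)c(Br)c2)C(=O)N1c1ccccc1C`) gives 1.6 mL.min-1.g-1. Compound 2 therefore has a single neighbour for comparison, and the two values lie within the usual scatter of each other.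

Compound 3 (`CCC/N=C1\S/C(=C\c2ccc(O)c(Cl)c2)C(=O)N1c1ccccc1C`) differs from compound 2 in one place: chloro in place of bromo on an aromatic carbon. In words, this is chloro in place of bromo on an aromatic carbon, ortho to a hydroxy group, turning 3-bromo-4-hydroxyphenyl into 3-chloro-4-hydroxyphenyl.

Going by the values given here, one measured step bears on this change. On that same aromatic carbon, bromo in place of trifluoromethyl gave a 1.6-fold higher number from compound 1 to compound 2 (0.20 log units; within the scatter), which stays within the scatter. Among the compounds with values here, no measured compound carries chloro, so this single step is the only guide, and it points to no clear direction. The expected step is a 1.1-fold lower number from compound 2 to compound 3 (0.06 log units; within the scatter), no larger than the scatter. For compound 3 the estimated value in this assay is 1.4 mL.min-1.g-1, with an expected range of 0.8 mL.min-1.g-1 to 2.4 mL.min-1.g-1.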

Compound 3, intrinsic clearance in microsomes: 1.6 mL.min-1.g-1
Compound 3: the middle estimate sits 1.1-fold (0.06 log units) below what was measured, within the range that was stated.
By their numbers in this assay, from the lowest: compounds 1, 2 and 3 (each within the scatter of the next).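

Compound 3 gives this position its first chloro reading: in this assay, chloro in place of bromo on this aromatic carbon, ortho to a hydroxy group, gave no change at the digits printed from compound 2 to compound 3 (within the scatter). Chloro in place of trifluoromethyl at the same carbon gave a 1.6-fold higher number from compound 1 to compound 3 (0.20 log units; within the scatter), so all three groups now compared at this position, trifluoromethyl, bromo and chloro, give numbers within the scatter of one another, whereas the earlier pair offered only one comparison. No measurement is available here that would explain these readings.

The three compounds show only these three groups at this position, so an amine, a carboxylic acid or a methoxy group there could give a number inside or outside this narrow band, and nothing shown points either way. Going by these compounds, all three compounds also share the same core and the same remaining groups, so it remains open whether chloro in place of bromo would read the same way if the propyl chain gave way to a longer chain.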